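This account rests on a few compounds, and the source may have more. Where it says the series, first, only, none or still open, it means among the compounds named here.

Measured so far in an ADME assay on MT4 cells (Homo sapiens) for cytotoxicity, read by MTT assay, with a stated time of 4 days; a higher number here means that more compound is tolerated, a lower number that less compound is tolerated:
- compound 1 `COc1ccc(-c2cc(C)c(Nc3ccnc(Nc4ccc(C#N)cc4)n3)c(C)c2)cc1` gives 2890 nM
- compound 2 `Cc1cc(-c2cccc(C#N)c2)cc(C)c1Nc1ccnc(Nc2ccc(C#N)cc2)n1` gives 920 nM

Within the data shown here, compound 2 thus holds the lowest of the two numbers; the only comparison is a 3.1-fold lower number from compound 1 to compound 2 (0.50 log units; beyond the scatter), which came with the change from a 4-methoxyphenyl to a 3-cyanophenyl.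

Compound 3 `Cc1cc(-c2ccc(Cl)cc2)cc(C)c1Nc1ccnc(Nc2ccc(C#N)cc2)n1` is not yet measured. It differs from compound 2 in one place: 4-chlorophenyl in place of 3-cyanophenyl on an aromatic carbon. Among the measured compounds shown here, no measured step swaps a 3-cyanophenyl for a 4-chlorophenyl, so the single step from compound 1 to compound 2 bears on it only loosely, as a sign that changing this ring can shift the number by a modest amount. Without a closer precedent, compound 3 is expected to stay near compound 2, a step of a 1.2-fold higher number from compound 2 to compound 3 (0.08 log units; within the scatter) in this assay, within the scatter. The estimate for compound 3 is 1100 nM, with a range from 400 nM to 3000 nM.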

Compound 3, half-maximal cytotoxic concentration: 4190 nM
Compound 3: the middle estimate sits 3.8-fold (0.58 log units) below what was measured, and the stated range ends below it.
By their numbers in this assay, from the lowest: compound 2; then compounds 1 and 3 (each within the scatter of the next).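

In this assay, replacing the 3-cyanophenyl with a 4-chlorophenyl gives a 4.6-fold higher number from compound 2 to compound 3 (0.66 log units; beyond the scatter), so a second change at this position moves the number beyond the scatter. Chloro in place of methoxy on the ring gives only a 1.4-fold higher number from compound 1 to compound 3 (0.16 log units; within the scatter), which means that these two groups cannot be told apart here, and compound 2, with its 3-cyanophenyl, stands apart from both of the others. Nothing available explains why this ring changes how much compound the cells tolerate.

Still open, from the compounds shown here alone, is whether the nitrile itself or its place on the ring sets compound 2 apart, since the nitrile and the change of ring position arrive together. A 4-cyanophenyl would separate the two, and a plain phenyl or a ring carrying an amine would show how far the range extends.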